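The source may hold more compounds than are shown below. What is called first, only, known or untested is meant among the compounds shown, and "the series" means these compounds.

The study follows a small set of compounds on a shared core in a physicochemical assay for solubility, at pH 7; a higher number here means a more soluble compound, a lower number a less soluble compound. Compound 1 (`CN1CCC(C(=O)N2Cc3c(NC(=O)NCc4ccccc4)n[nH]c3C2(C)C)CC1`) gives > 225000 nM, which is a limit of the assay and not a number. Compound 2 (`CN1CCC(C(=O)N2Cc3c(NC(=O)c4cccc(F)c4)n[nH]c3C2(C)C)CC1`) gives > 225000 nM, again only a limit. Compound 2 therefore has no exact standing, and the evidence shown is the limit of > 225000 nM in this assay, at which 2 of the 2 values shown sit. Going by the values given here, the one measured step that bears on what follows is a step that the two limits leave unreadable from compound 1 to compound 2, so it offers no size to carry forward. Compound 3 (`CN1CCC(C(=O)N2Cc3c(NC(=O)c4ccccc4)n[nH]c3C2(C)C)CC1`) differs from compound 2 by hydrogen in place of fluoro on an aromatic carbon, which is hydrogen in place of fluoro on an aromatic carbon. With no readable step to suggest otherwise, no change beyond the scatter is expected in this assay, in either direction. The expected step is a step that the limit leaves unreadable from compound 2 to compound 3. For compound 3 the estimate is 230000 nM, with an expected range from 120000 nM to 400000 nM.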

Compound 3, solubility: > 225000 nM
Compound 3 gave a limit, no number (the forecaster's own chance of this, stated with the estimate: 85%); the middle value is on the limit's open side.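

Going by these compounds alone, compound 3 also stops at a limit and not a number, so no step among compound 1, compound 2 and compound 3 can be read: the limit of > 225000 nM in this assay, at which 3 of the 3 values shown sit. The compounds shown leave open how far each lies past that limit, and which change on the shared core would give a readable value.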